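A Dimethylamino Group on the Aromatic Ring of Compound 1

This account rests on a few compounds, and the source may have more. Where it says the series, first, only, none or still open, it means among the compounds named here.

Measured compounds:
- compound 1 `O=C1C=CCC/C1=C\C=C\c1ccccc1`: 4200 nM
- compound 2 `CC(=C\c1ccccc1)/C=C1\CCC=CC1=O`: 3900 nM

In a functional assay on Bel-7402 cells (Homo sapiens) for cytotoxicity, read by MTT assay, with a stated time of 72 h (on this read-out lower numbers stand for stronger inhibition and higher numbers for weaker inhibition), compound 1 gives the higher of the two numbers. Within the data shown here, the one measured step, a 1.1-fold lower number from compound 1 to compound 2 (0.03 log units; within the scatter), lies within the scatter, so the two values show no difference that can be read.

Compound 3 `CN(C)c1ccc(/C=C/C=C2\CCC=CC2=O)cc1` has not been measured. It differs from compound 1 by dimethylamino in place of hydrogen on an aromatic carbon, the place being on the aromatic ring that the dienone chain carries. Among the measured compounds shown here, the measured step concerns the chain, not the ring, so it does not bear on this change, and no step from the data tells what a group on the ring does. The estimate for compound 3 therefore rests on compound 1 alone, with a wide range, and is expected to be 3000 nM between 900 nM and 10000 nM. The step this estimate means, a 1.4-fold lower number from compound 1 to compound 3 (0.15 log units; within the scatter), is expected to stay near the scatter.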

Compound 3, half-maximal inhibitory concentration: 900 nM
Compound 3: the middle estimate sits 3.3-fold (0.52 log units) above what was measured; the measured number falls inside the stated range.
By their numbers in this assay, from the lowest: compound 3; then compounds 2 and 1 (each within the scatter of the next).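

In this assay, dimethylamino in place of hydrogen on an aromatic carbon, para to a large group, gives a 4.7-fold lower number from compound 1 to compound 3 (0.67 log units; beyond the scatter), a modest step but one beyond the scatter. This is the first change among the compounds shown that clearly moves the number: the aromatic ring is a place where a new group can alter the read-out, whereas the methyl on the chain in compound 2 left it within the scatter of compound 1. Nothing measured here explains why the number falls with this group.

From the compounds shown here alone, it remains open whether the drop belongs to dimethylamino in particular or would also appear with another group on the same carbon, such as a methoxy group, a primary amine or a chlorine atom. Going by these compounds, it is also open whether the chain methyl and the ring dimethylamino would work together in one compound.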